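Aryl change on the sulfonamide nitrogen: compound 4

The source may report more compounds than this note shows. Statements on the series, on what has been measured and on what is new or still open speak of the compounds shown alone.

Compound 1 `Cc1ccc(NS(=O)(=O)c2ccc(N3CCNC3=O)cc2)cc1C` with 230 nM
Compound 2 `CC(C)(C)c1ccc(NS(=O)(=O)c2ccc(N3CCNC3=O)cc2)cc1` with > 1000 nM as a limit of the assay
Compound 3 `Cc1cc(C)cc(NS(=O)(=O)c2ccc(N3CCNC3=O)cc2)c1` with 100 nM

In a functional assay on MCF7 cells (Homo sapiens) for antiproliferative activity, read by sulforhodamine B assay, with a stated time of 48 h (a lower number here means a stronger inhibitor, a higher number a weaker inhibitor), compound 3 gives 100 nM as the lowest of the two numbers available. Compound 4 `O=C1NCCN1c1ccc(S(=O)(=O)Nc2ccc(Br)cc2)cc1` is not yet measured and carries 4-bromophenyl in place of 3,5-dimethylphenyl on a sulfonamide nitrogen. Going by the values given here, the one measured step at this place, a 2.3-fold lower number from compound 1 to compound 3 (0.36 log units; beyond the scatter), is modest. Among the compounds with values here, compound 2 gives > 1000 nM as a limit and adds no step. Since compound 3 already holds 100 nM as the lowest number, a modest rise is expected. The expected change is a 3.0-fold higher number from compound 3 to compound 4 (0.48 log units; beyond the scatter) toward a higher number. Compound 4 is estimated at 300 nM with 110 nM to 1000 nM as the expected range.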

Compound 4, half-maximal inhibitory concentration: 240 nM
Beside the measured number, compound 4's estimate is 1.3-fold (0.10 log units) above it; low and high end bracket the measured number.
By their numbers in this assay, from the lowest: compound 3; then compounds 1 and 4 (each within the scatter of the next). At a limit, above all of these: compound 2.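

In this assay, 4-bromophenyl on the sulfonamide nitrogen is not separated from 3,4-dimethylphenyl, with a 1.0-fold higher number from compound 1 to compound 4 (0.02 log units; within the scatter). It does trail 3,5-dimethylphenyl, with a 2.4-fold higher number from compound 3 to compound 4 (0.38 log units; beyond the scatter), so a single bromo serves here about as well as the two methyl groups of compound 1 but not those of compound 3. Bromo in place of tert-butyl gives an at least 4.1-fold lower number from compound 2 to compound 4 (0.61 log units; beyond the scatter), and this step rests on a limit for compound 2: the limit of > 1000 nM in this assay, at which 1 of the 4 values shown sits.

Open, on these data alone, is whether chloro, methoxy or an amine in place of the bromo would hold this level. Also open, as far as these compounds go, is whether 3,5-dibromophenyl would follow 3,5-dimethylphenyl.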